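Trifluoromethyl added to a chlorophenyl adenosine receptor binder

This account rests on a few compounds, and the source may have more. Where it says the series, first, only, none or still open, it means among the compounds named here.

Compound 1 (`CN1CCN(c2nc(-c3ccc(Cl)cc3)nc3[nH]cnc23)CC1`) was tested in an assay on cells for displacement of a labelled ligand from adenosine receptor A3 (Homo sapiens), read by scintillation counting and radioligand binding, with a stated time of 180 min, tested at 10 uM; a lower number here means less inhibition, a higher number more inhibition at the concentration tested (going by the name of the read-out). In this assay compound 1 gives > 80%, which is a limit of the assay and not an exact number. The value of compound 1 sits at the top end of the measured values, as noted in the limit of > 80% in this assay, at which 1 of the 2 values shown sits. Compound 2 (`CN1CCN(c2nc(-c3cccc(Cl)c3)nc3c2ncn3C)CC1`), which has a different core and a different placement of its chloro group, gives 38.3% in this assay.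

Compound 3 (`CN1CCN(c2nc(-c3ccc(Cl)c(C(F)(F)F)c3)nc3[nH]cnc23)CC1`) has not yet been measured. It differs from compound 1 by trifluoromethyl in place of hydrogen on an aromatic carbon. Going by the values given here, no measured pair shows what this change does. Since only a limit is known for compound 1, the step cannot be sized from data; the expectation is a step that stays within the usual scatter, or a modest drop at most.

Compound 3 is expected to give 75%, with a range from 45% to 95%. The step of a number at least 5 percentage points lower from compound 1 to compound 3 (that floor lies within the scatter) is thus expected to be small.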

Compound 3, a percentage reported as inhibition, at one concentration (the size of the read-out at that concentration, not a potency): > 80%
Compound 3: only a limit was reported (the forecaster's own chance of this, stated with the estimate: 40%); middle value at least 5 percentage points from the limit.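

No step can be read from compound 1 to compound 3: each of the two gives only a limit of the assay, not an exact number. The compounds shown leave open whether trifluoromethyl in place of hydrogen on an aromatic carbon changes inhibition at all.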